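Ethyl for Methoxy: Expected Cytotoxicity of Compound 4

The source may report more compounds than this note shows. Statements on the series, on what has been measured and on what is new or still open speak of the compounds shown alone.

Compound 1 `COc1ccc(C(=O)Nc2cc3nc(C4CCCCC4)[nH]c3cc2N(C)C)cc1` gives > 100 ug/mL, a limit of the assay.
Compound 2 `COc1ccc(C(=O)Nc2cc3nc(C4CCCCC4)[nH]c3cc2N2CCCC2)cc1` gives > 100 ug/mL, a limit of the assay.
Compound 3 `CCOCCOC(=O)Nc1cc2nc(C3CCCCC3)[nH]c2cc1N1CCCC1` gives > 100 ug/mL, a limit of the assay.

These three compounds were tested in an ADME assay on Vero cells (Chlorocebus sabaeus) for cytotoxicity, read by resazurin assay, with a stated time of 3 days; on this read-out lower numbers stand for stronger inhibition and higher numbers for weaker inhibition. In this assay compound 1 does not stand at a measured number at all: its result is a limit, and the same holds for the two other compounds, as summarised by the limit of > 100 ug/mL in this assay, at which 3 of the 3 values shown sit. Because of this, the step that the two limits leave unreadable from compound 1 to compound 2 cannot be read, and neither can the step that the two limits leave unreadable from compound 2 to compound 3. Going by the values given here, no step has a readable size.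

Compound 4 `CCc1ccc(C(=O)Nc2cc3nc(C4CCCCC4)[nH]c3cc2N(C)C)cc1` differs from compound 1 by one change: ethyl in place of methoxy on an aromatic carbon. Neither of the measured steps touches this part of the molecule, and even the steps that exist give no number to build on. What the data do show is that every compound of this shape so far stays at the limit, so compound 4 is expected to do the same, with a step that the limit leaves unreadable from compound 1 to compound 4 that means no change beyond the scatter. Compound 4 is therefore estimated at 120 ug/mL, within a range from 50 ug/mL to 300 ug/mL.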

Compound 4, half-maximal inhibitory concentration: > 100 ug/mL
Compound 4 ended at the assay's limit; the forecaster's own chance of this, stated with the estimate: 80%; the middle value is on the limit's open side.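

No size can be given for the step from methoxy in compound 1 to ethyl in compound 4, because both results are limits of the assay and not numbers: the limit of > 100 ug/mL in this assay, at which 4 of the 4 values shown sit.

The compounds shown leave open how toxic any of them is to the cells in this assay, and which structural change, if any, would alter that result.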